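A few compounds are considered here, and "the series" means these few. Any claim that something is new, unique, unknown or untested is made for them only; others in the source may bear on it.

Working notes on the chromenone series and an assay on isolated protein for inhibition of Amine oxidase [flavin-containing] B (Homo sapiens), read by fluorescence and spectrophotometry; a lower number here means a stronger inhibitor, a higher number a weaker inhibitor.

Of the compounds shown here, three of the shared core have numbers so far. Compound 1 `Cc1ccc(NC(=O)CCCCc2cn(Cc3ccc4oc(-c5ccc(Cl)cc5)cc(=O)c4c3)nn2)cc1` gives 32900 nM in this assay. Compound 2 `Cc1ccc(C(=O)NCc2cn(Cc3ccc4oc(-c5ccc(Cl)cc5)cc(=O)c4c3)nn2)cc1` gives 32900 nM, level with compound 1 at the digits shown, and the two together stand at the high end of the three; the gap between them lies within the scatter, so no order is read into it. Compound 3 `O=C(CCCCc1cn(Cc2ccc3oc(-c4ccccc4)cc(=O)c3c2)nn1)Nc1ccc(F)cc1` gives 15600 nM, the lowest of the three numbers and beyond the scatter from compound 2.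

The next compound, compound 4 `O=C(CCCCc1cn(Cc2ccc3oc(-c4ccc(Cl)cc4)cc(=O)c3c2)nn1)Nc1ccccc1`, is not yet measured. It differs from compound 2 in one place: 3-(phenylcarbamoyl)propyl in place of ((4-methylphenyl)carbonyl)amino on a saturated chain carbon bound to an aromatic carbon. The change puts the carbonyl and the amide hydrogen at the far end of a chain rather than directly on the triazole, with a phenyl that carries no substituent.

Among the compounds with values here, no measured pair tells this exact step. Compound 1 holds the same chain with a 4-methylphenyl and the same core, and compound 3 holds the same chain with a 4-fluorophenyl on a core without chlorine; their values bracket what is reasonable here. The step from compound 2 to compound 4 is expected to be small, towards a lower number or none beyond the scatter, at a 1.4-fold lower number from compound 2 to compound 4 (0.14 log units; within the scatter). For compound 4 the estimate in this assay is 24000 nM, with a range from 10000 nM to 60000 nM.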

Compound 4, half-maximal inhibitory concentration: 32900 nM
Compound 4: middle estimate off by 1.4-fold (0.14 log units), on the low side; measured number inside the range.
By their numbers in this assay, from the lowest: compound 3; then compounds 1, 2 and 4 (each within the scatter of the next).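

In this assay, within the data shown here, 3-(phenylcarbamoyl)propyl in place of ((4-methylphenyl)carbonyl)amino on a saturated chain carbon bound to an aromatic carbon gives no change at the digits printed from compound 2 to compound 4 (within the scatter) and thus the first one-place reading at this position: with the carbonyl and the amide hydrogen kept but set further along the chain, the change does not separate the two compounds. Hydrogen in place of methyl on an aromatic carbon gives no change at the digits printed from compound 1 to compound 4 (within the scatter), so with this chain and the shared core, the methyl group makes no difference that can be read. Nothing at hand bears on why these values coincide.

Among these compounds, compound 3 at 15600 nM differs from compound 4 in more than one place, so no step to it can be read, and the separate contributions of its fluorine and of the chlorine on the core remain unresolved. Also open, as far as these compounds go, is whether a longer chain, or a carboxylic acid or an amine at the chain end in place of the phenyl amide, would move the number away from the level shared by compounds 1, 2 and 4.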